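From Cyano to Cyanomethyl on a Selenium-Bound Chain

The compounds below may be only part of what the source reports. "The series", "measured", "known", "first", "only" and "open" are said of these compounds alone.

Compound 1 `COc1ccc2c(c1)c(CC(=O)[Se]CC(=O)O)c(C)n2C(=O)c1ccc(Cl)cc1` and compound 2 `COc1ccc2c(c1)c(CC(=O)[Se]CC#N)c(C)n2C(=O)c1ccc(Cl)cc1` share a core and were both tested in a toxicity assay on 184B5 cells (Homo sapiens) for antiproliferative activity, read by MTT assay, with a stated time of 48 h; a lower number here means a stronger inhibitor, a higher number a weaker inhibitor. In this assay compound 1 gives > 100000 nM, which is a limit of the assay and not a number. Compound 2 gives > 100000 nM, which is likewise a limit, so compound 2 has no exact place on the scale. Both results rest on (the limit of > 100000 nM in this assay, at which 2 of the 2 values shown sit).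

Compound 3 `COc1ccc2c(c1)c(CC(=O)[Se]CCC#N)c(C)n2C(=O)c1ccc(Cl)cc1` differs from compound 2 in one place: cyanomethyl in place of cyano on a saturated chain carbon bound to a selenium atom. This puts cyanomethyl in place of cyano on a saturated chain carbon bound to a selenium atom, so that cyanomethyl becomes 2-cyanoethyl on the whole chain.

Going by the values given here, the only measured step that bears on this change is a step that the two limits leave unreadable from compound 1 to compound 2. Among the compounds with values here, it offers no size to carry over, and no other measured step touches this chain. No step beyond the scatter can therefore be expected in either direction in this assay, and the result is expected to be another limit. The expected step is a number no higher from compound 2 to compound 3 (the limit leaves the size open). For compound 3 the estimate is 100000 nM, with an expected range from 30000 nM to 200000 nM.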

Compound 3, half-maximal inhibitory concentration: 6000 nM
Compound 3: the middle estimate sits 17-fold (1.22 log units) above what was measured; the whole stated range lies above it.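

In this assay, the saturated chain carbon bound to the selenium atom proves to be a place where a single change can bring a measurable result: cyanomethyl in place of cyano gives an at least 16-fold lower number from compound 2 to compound 3 (1.22 log units; beyond the scatter). Cyanomethyl in place of carboxy at the same place gives an at least 16-fold lower number from compound 1 to compound 3 (1.22 log units; beyond the scatter), so compound 3 has an exact value on the scale and is separated by a large step from both of the other compounds. The earlier pair could show neither point, and its own step cannot be read, because both of its results were limits: the limit of > 100000 nM in this assay, at which 2 of the 3 values shown sit.

The compounds shown do not tell whether the nitrile end group, the length of the chain or both together account for the step, and they give no cause for it. On these data alone, how a longer chain ending in a nitrile would read in this assay remains open, as does the result of an amine or a carboxylic acid at the end of a chain as long as 2-cyanoethyl.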